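The source may hold more compounds than are shown below. What is called first, only, known or untested is meant among the compounds shown, and "the series" means these compounds.

Measured compounds:
- compound 1, `Oc1ccc(-c2cc(-c3ccc(F)cc3)cc(-c3cccc(O)c3)n2)cc1`: 5020 nM
- compound 2, `Oc1cccc(-c2cc(-c3cccc(C(F)(F)F)c3)cc(-c3ccccc3O)n2)c1`: 6460 nM

Both numbers come from a functional assay on HCT-15 cells (Homo sapiens) for inhibition; a higher number here means a weaker inhibitor, a lower number a stronger inhibitor. Compound 2 has the higher of the two numbers, but its gap to compound 1 lies within the scatter, so the two cannot be told apart on these data.

Compound 3, `Oc1ccc(-c2cc(-c3cccc(C(F)(F)F)c3)cc(-c3cccc(O)c3)n2)cc1`, is the next step from compound 2. The change is 4-hydroxyphenyl in place of 2-hydroxyphenyl on an aromatic carbon. The two compounds have the same atoms joined differently, so only the position of one hydroxyl on its ring moves. Among the compounds with values here, no step between measured compounds isolates this change, and the two numbers known so far sit within the scatter of each other, so there is nothing to point in either direction. For this assay the expected step from compound 2 to compound 3 is a 1.2-fold lower number from compound 2 to compound 3 (0.07 log units; within the scatter), which is none beyond the scatter. Compound 3 is therefore estimated at 5500 nM, with a range from 1800 nM to 17000 nM.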

Compound 3, half-maximal inhibitory concentration: 9540 nM
Estimate against measurement, compound 3: 1.7-fold (0.24 log units) below; measured number inside the range.
By their numbers in this assay, from the lowest: compounds 1, 2 and 3 (each within the scatter of the next).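

In this assay, 4-hydroxyphenyl in place of 2-hydroxyphenyl, on the aromatic carbon next to the ring nitrogen, gives a 1.5-fold higher number from compound 2 to compound 3 (0.17 log units; within the scatter), so this first one-place comparison shows no readable effect of where the hydroxyl sits on that ring. The second comparison, 3-(trifluoromethyl)phenyl in place of 4-fluorophenyl on an aromatic carbon, gives a 1.9-fold higher number from compound 1 to compound 3 (0.28 log units; within the scatter), so that swap cannot be told apart from repeat scatter either. No supporting measurement bears on these results.

The compounds shown leave open whether this ring needs its hydroxyl at all, as a plain phenyl ring would test. They also leave open whether an amine or a carboxylic acid on this ring would move the number beyond the scatter.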